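From 2-chlorophenyl to 4-chlorophenyl: an estimate

The source may hold more compounds than are shown below. What is called first, only, known or untested is meant among the compounds shown, and "the series" means these compounds.

Compound 1 `COc1ccc(Nc2nc(Nc3cnn(CCCCCCC(=O)NO)c3)ncc2Cl)cc1`: 130 nM
Compound 2 `O=C(CCCCCCn1cc(Nc2ncc(Cl)c(Nc3ccccc3Cl)n2)cn1)NO`: 250 nM

For the measured compounds named here, compound 2 cannot be told apart from the only other compound measured in a functional assay on Jurkat cells (Homo sapiens) for antiproliferative activity, read by MTT assay, with a stated time of 48 h; on this read-out lower numbers stand for stronger inhibition and higher numbers for weaker inhibition. The step between them reads a 1.9-fold higher number from compound 1 to compound 2 (0.28 log units; within the scatter). Compound 3 `O=C(CCCCCCn1cc(Nc2ncc(Cl)c(Nc3ccc(Cl)cc3)n2)cn1)NO` has not been measured. It differs from compound 2 by 4-chlorophenyl in place of 2-chlorophenyl on a nitrogen on an aromatic ring, with 4-chlorophenyl in place of 2-chlorophenyl on a nitrogen on an aromatic ring. Going by the values given here, no measured step makes this exact exchange. Among the compounds with values here, the one step at this place, a 1.9-fold higher number from compound 1 to compound 2 (0.28 log units; within the scatter), stayed within the scatter, so no change beyond the scatter is expected in this assay. The expected step is a 1.3-fold lower number from compound 2 to compound 3 (0.12 log units; within the scatter). Compound 3 is estimated at 190 nM, with an expected range of 80 nM to 450 nM.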

Compound 3, half-maximal inhibitory concentration: 100 nM
Compound 3: middle estimate off by 1.9-fold (0.28 log units), on the high side; measured number inside the range.
By their numbers in this assay, from the lowest: compounds 3, 1 and 2 (each within the scatter of the next, the first and the last beyond it).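

In this assay, for the compounds shown here, 4-chlorophenyl in place of 2-chlorophenyl on a nitrogen on an aromatic ring gives a 2.5-fold lower number from compound 2 to compound 3 (0.40 log units; beyond the scatter), the first step at this place beyond the scatter, so where the chloro sits on this phenyl does register in the read-out. Chloro in place of methoxy on an aromatic carbon gives a 1.3-fold lower number from compound 1 to compound 3 (0.11 log units; within the scatter), which leaves compound 1 and compound 3 indistinguishable. Nothing at hand bears on why the chloro's place matters.

From the compounds shown here alone, whether 2-methoxyphenyl would differ from 4-methoxyphenyl as 2-chlorophenyl differs from 4-chlorophenyl stays open. So does what 4-fluorophenyl or 4-aminophenyl would give on this nitrogen.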